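The source may report more compounds than this note shows. Statements on the series, on what has been measured and on what is new or still open speak of the compounds shown alone.

Working notes on the series. In a functional assay on NCI-H460 cells (Homo sapiens) for antiproliferative activity, read by MTT assay, with a stated time of 72 h (on this read-out lower numbers stand for stronger inhibition and higher numbers for weaker inhibition), compound 1 (`O=c1c(-c2ccc(F)cc2)c[nH]c2ccnc(Nc3ccc(Oc4ccnc5cc(OCCO)ccc45)c(F)c3)c12`) gives 3500 nM, compound 2 (`CC(C)(O)COc1ccc2c(Oc3ccc(Nc4nccc5[nH]cc(-c6ccc(F)cc6)c(=O)c45)cc3F)ccnc2c1`) gives 3200 nM and compound 3 (`COCCOc1cc2nccc(Oc3ccc(Nc4nccc5[nH]cc(-c6ccc(F)cc6)c(=O)c45)cc3F)c2cc1OC`) gives 3000 nM. Compound 2 therefore stands within the scatter of both other compounds, and no order can be read among the three.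

Compound 4 (`O=c1c(-c2ccc(F)cc2)c[nH]c2ccnc(Nc3ccc(Oc4ccnc5cc(O)ccc45)c(F)c3)c12`) has not yet been measured. Its difference from compound 2 is hydrogen in place of 2-hydroxy-2-methylpropyl on an oxygen on an aromatic ring; cut one bond further out, this reads 2-hydroxy-2-methylpropoxy to hydroxy.

Going by the values given here, only one measured step bears on this change: a 1.1-fold lower number from compound 1 to compound 2 (0.04 log units; within the scatter), with 1-hydroxy-1-methylethyl in place of hydroxymethyl on a saturated chain carbon. That step alters the end of the chain and does not remove it, so it is only partial guidance. Among the compounds with values here, no measured compound lacks the chain, so the removal itself is untested. Compound 3, with a different chain, still gives 3000 nM.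

No shift beyond the scatter is therefore expected in this assay, and no direction can be supported, though the uncertainty is wide. The expected step is a 1.1-fold higher number from compound 2 to compound 4 (0.04 log units; within the scatter), which stays within the scatter. For compound 4 the estimated value is 3500 nM, with an expected range of 1300 nM to 9000 nM.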

Compound 4, half-maximal inhibitory concentration: 43000 nM
For compound 4 the middle estimate is 12-fold (1.09 log units) below the measured one; the measured number lies above the stated range.
By their numbers in this assay, from the lowest: compounds 3, 2 and 1 (each within the scatter of the next); then compound 4.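

In this assay, changes at the end of the chain on this oxygen had left the number within the scatter, as in a 1.1-fold lower number from compound 1 to compound 2 (0.04 log units; within the scatter), but removing the chain altogether is not tolerated. Hydroxy in place of 2-hydroxy-2-methylpropoxy gives a 13-fold higher number from compound 2 to compound 4 (1.13 log units; beyond the scatter), and hydrogen in place of 2-hydroxyethyl on the same oxygen gives a 12-fold higher number from compound 1 to compound 4 (1.09 log units; beyond the scatter), so two different chains lead to a step of similar size and both stand well clear of the bare hydroxy compound. No measurement at hand speaks to the origin of this shift.

The compounds shown leave open how much of the chain is needed, since both chains compared with compound 4 end in a hydroxy-bearing carbon and nothing here separates the chain carbons from that hydroxy, as a plain ethyl group on the oxygen would. They also leave open whether a terminal amine, a carboxylic acid or a longer chain on this oxygen would hold the number near that of compound 2 at 3200 nM or move it further in either direction.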